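Replacing 3-fluorophenyl with 3,5-dimethoxyphenyl on the shared core

This account rests on a few compounds, and the source may have more. Where it says the series, first, only, none or still open, it means among the compounds named here.

Of the compounds shown here, three sharing one core have been measured in a functional assay on MDA-MB-231 cells (Homo sapiens) for antiproliferative activity, read by MTT assay, with a stated time of 72 h; on this read-out lower numbers stand for stronger inhibition and higher numbers for weaker inhibition. Compound 1 `O=C(CCc1cccc2c1B(O)OC2)Nc1ccc(Br)cc1` gives 5300 nM. Compound 2 `O=C(CCc1cccc2c1B(O)OC2)Nc1ccc2ccccc2c1` gives 1800 nM. Compound 3 `O=C(CCc1cccc2c1B(O)OC2)Nc1cccc(-c2cccc(F)c2)c1` gives 570 nM, the lowest number of the three, and its gaps to both compound 2 and compound 1 lie beyond the usual scatter of repeated measurements.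

Compound 4 `COc1cc(OC)cc(-c2cccc(NC(=O)CCc3cccc4c3B(O)OC4)c2)c1` has not yet been measured. It differs from compound 3 in one place 3,5-dimethoxyphenyl in place of 3-fluorophenyl on an aromatic carbon, meta to a large group. Within the data shown here, no measured pair differs in only one place, so the data offer no direct guide to the size of this step. The expectation rests on compound 3 at 570 nM, since the entering group is again a six-membered aromatic ring of carbon only. The expected step is a 1.1-fold higher number from compound 3 to compound 4 (0.02 log units; within the scatter), an estimate that stays within the scatter, with no clear direction. In this assay the estimate for compound 4 is 600 nM, expected to lie between 200 nM and 1800 nM.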

Compound 4, half-maximal inhibitory concentration: 40 nM
The estimate for compound 4 lay 15-fold (1.18 log units) above the measured number; measured number below the stated range.
By their numbers in this assay, from the lowest: compound 4; then compound 3; then compound 2; then compound 1.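

In this assay, putting 3,5-dimethoxyphenyl in place of 3-fluorophenyl gives a 14-fold lower number from compound 3 to compound 4 (1.15 log units; beyond the scatter) and makes compound 4 the lowest number of the series. Among these compounds, the earlier compounds differ from one another in more than one place, so this is the first direct reading of a single change on the shared core, and it shows that this position, an aromatic carbon meta to a large group, responds strongly to what the attached ring carries, even though the ring itself stays six-membered, aromatic and of carbon only. Nothing available explains why the change is this large.

On these data alone, it remains open whether a single methoxy group would give the same step as two. A 3,5-dimethylphenyl group, or a ring carrying an amine, would test whether the oxygen atoms matter here.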